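The source may hold more compounds than are shown below. What is called first, only, known or untested is meant among the compounds shown, and "the series" means these compounds.

Measured compounds:
compound 1 `C[C@@H](Oc1cc2oc(=O)n(CCC(=O)O)c2cc1Cl)c1ccc(F)cn1`, 2.51 nM
compound 2 `C[C@@H](Oc1cc2oc(=O)n(CCC(=O)O)c2cc1Cl)c1cccnn1`, 1.26 nM

Going by the values given here, in an assay for inhibition of kynurenine 3-monooxygenase (Homo sapiens), read by mass spectrometry, with a stated time of 1 h (on this read-out higher numbers stand for weaker inhibition and lower numbers for stronger inhibition), compound 2 stands at the lowest of the two numbers, with compound 1 as its only neighbour at 2.51 nM; the one measured step, a 2.0-fold lower number from compound 1 to compound 2 (0.30 log units; within the scatter), stays within the scatter, so the two compounds cannot be ordered.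

Compound 3 `C[C@@H](Oc1cc2oc(=O)n(CCC(=O)O)c2cc1Cl)c1ccc(Cl)cn1` is not yet measured. It differs from compound 2 in one place: 5-chloropyridin-2-yl in place of pyridazin-3-yl on a saturated chain carbon bound to an oxygen on an aromatic ring and a saturated chain carbon. Among the compounds with values here, the only step that bears on this is a 2.0-fold lower number from compound 1 to compound 2 (0.30 log units; within the scatter), which exchanged a fluorine-bearing pyridin-2-yl for pyridazin-3-yl and moved the number only within the scatter. The change to compound 3 runs back from pyridazin-3-yl to a pyridin-2-yl, now bearing chlorine in place of fluorine, the group class present in compound 1. Within the data shown here, no step in this assay speaks for a move beyond the scatter. Compound 3 is therefore expected near the two measured values, at 2 nM (range 0.8 nM to 5 nM), an expected step of a 1.6-fold higher number from compound 2 to compound 3 (0.20 log units; within the scatter).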

Compound 3, half-maximal inhibitory concentration: 3.16 nM
Compound 3: middle estimate off by 1.6-fold (0.20 log units), on the low side; low and high end bracket the measured number.
By their numbers in this assay, from the lowest: compounds 2, 1 and 3 (each within the scatter of the next, the first and the last beyond it).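

In this assay, going by these compounds alone, the step of a 2.5-fold higher number from compound 2 to compound 3 (0.40 log units; beyond the scatter) is the first change on this saturated chain carbon to pass beyond the scatter, so pyridazin-3-yl and 5-chloropyridin-2-yl can be ordered here, though only by a modest margin. The step of a 1.3-fold higher number from compound 1 to compound 3 (0.10 log units; within the scatter), chloro in place of fluoro on an aromatic carbon, stays within the scatter, so that exchange separates nothing, and compound 2 is set apart from compound 3 but not from compound 1. No measured evidence bears on the reason for the step from pyridazin-3-yl.

The step to compound 3 changes both the ring hetero atoms and the chlorine, and the compounds shown do not separate the two; an unsubstituted pyridin-2-yl would. Going by these compounds, whether a methoxy or nitrile in place of the halogen would leave the number within the scatter also stays open.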